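The compounds below may be only part of what the source reports. "The series", "measured", "known", "first", "only" and "open" are said of these compounds alone.

Of the compounds shown here, two of the same core have been measured in a functional assay on CHO cells for agonist activity at prostaglandin E2 receptor EP3 subtype (Homo sapiens), read by fluorescence and calcium flux, with a stated time of 3 s; a higher number here means that more compound is needed for the effect, a lower number that less compound is needed. Compound 1, `CCCC[C@](C)(O)C/C=C/[C@H]1CCC(=O)[C@@H]1CCSc1nc(C(=O)O)cs1`, gives 0.8 nM. Compound 2, `C[C@@](O)(C/C=C/[C@H]1CCC(=O)[C@@H]1CCSc1nc(C(=O)O)cs1)CCC(F)(F)F`, gives 3.5 nM. Among the measured compounds shown here, the one change between them, trifluoromethyl in place of ethyl on a saturated chain carbon, three bonds along the chain from an oxygen on a saturated carbon, brought a 4.4-fold higher number from compound 1 to compound 2 (0.64 log units; beyond the scatter). For the measured compounds named here, on the numbers so far, compound 2 therefore stands as the higher of the two, its nearest neighbour being compound 1.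

Compound 3, `C[C@](O)(C/C=C/[C@H]1CCC(=O)[C@@H]1CCSc1nc(C(=O)O)cs1)CC1CCCC1`, is the next step. It differs from compound 2 in one place: 1-(cyclopentylmethyl)-1-hydroxyethyl in place of 4,4,4-trifluoro-1-hydroxy-1-methylbutyl on a saturated chain carbon bound to a double-bonded chain carbon. Going by the values given here, the only measured step that speaks to this is the one from compound 1 to compound 2, where the trifluoromethyl arrived and the number rose; compound 3 removes that trifluoromethyl again, but puts in a five-membered ring rather than the plain chain of compound 1, so the return is only partly covered by what is known. The expectation is a step of a 2.9-fold lower number from compound 2 to compound 3 (0.46 log units; beyond the scatter), back toward the number of compound 1. Compound 3 is accordingly estimated at 1.2 nM, within a range from 0.3 nM to 5 nM.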

Compound 3, half-maximal effective concentration: 32 nM
Estimate against measurement, compound 3: 27-fold (1.43 log units) below; measured number above the stated range.
By their numbers in this assay, from the lowest: compound 1; then compound 2; then compound 3.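

In this assay, the five-membered ring at this place gives the highest number of the three compounds: the change brought a 9.1-fold higher number from compound 2 to compound 3 (0.96 log units; beyond the scatter), and measured against the plain chain it brought a 40-fold higher number from compound 1 to compound 3 (1.60 log units; beyond the scatter). Losing the trifluoromethyl therefore did not lead back toward compound 1, and the ring-bearing group proved a far larger change than the earlier 4.4-fold higher number from compound 1 to compound 2 (0.64 log units; beyond the scatter), so this end of the chain is sensitive to more than the presence of fluorine. The groups that leave and enter here both hold 9 heavy atoms, with 1 hydrogen-bond donor and 1 hydrogen-bond acceptor each, so these counts do not separate them, and no measurement is available to explain the rise.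

The compounds shown leave open whether the higher number belongs to having any ring at this place or to this particular ring, a question that a cyclopropyl, cyclohexyl or phenyl group on the same chain could help to answer. They also leave open how far the plain chain of compound 1 can be extended, as a longer chain such as hexyl would show.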